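The source may hold more compounds than are shown below. What is called first, only, known or untested is meant among the compounds shown, and "the series" means these compounds.

The series opens with compound 1, `CCCCc1nc2ncccc2n1Cc1cc(Cl)c(O)c(Cl)c1`, which in a functional assay (aorta) with Oryctolagus cuniculus as the target (a higher number here means weaker binding, a lower number tighter binding), gives 398 nM. Among the measured compounds shown here, compound 2, `Cc1ccnc2c1nc(C)n2Cc1ccc(-c2ccccc2C(=O)O)cc1`, carries a different core and a biphenyl carboxylic acid, and in this assay compound 2 gives 50.1 nM, the lower of the two numbers measured so far; the gap between compound 2 and compound 1 lies beyond the scatter. For the measured compounds named here, no pair of measured compounds differs in a single place, so the only guide to the next step is the structural change itself.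

Compound 3, `Cc1ccnc2c1nc(CCCO)n2Cc1ccc(-c2ccccc2C(=O)O)cc1`, has not yet been measured in this assay. It differs from compound 2 as follows: 2-hydroxyethyl in place of hydrogen on a saturated chain carbon bound to an aromatic carbon. The change keeps the biphenyl carboxylic acid and the core of compound 2 untouched and extends only the saturated chain carbon bound to an aromatic carbon.

Going by the values given here, with no matched pair measured, the expectation leans on compound 2 alone, and a step of a 1.7-fold lower number from compound 2 to compound 3 (0.22 log units; within the scatter) toward a somewhat lower number is expected in this assay, a movement that may stay within the scatter. For compound 3 the estimate in this assay is 30 nM, with a range from 8 nM to 120 nM.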

Compound 3, dissociation constant: 501 nM
Compound 3: the middle estimate sits 17-fold (1.22 log units) below what was measured; measured number above the stated range.
By their numbers in this assay, from the lowest: compound 2; then compounds 1 and 3 (each within the scatter of the next).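

In this assay, among the compounds shown here, compounds 2 and 3 form the first pair that differs in one place, and they show that this position is sensitive to the change: with the core and the biphenyl carboxylic acid held constant, 2-hydroxyethyl in place of hydrogen on a saturated chain carbon bound to an aromatic carbon gives a 10-fold higher number from compound 2 to compound 3 (1.00 log units; beyond the scatter). Cut one bond further out, the same difference reads methyl to 3-hydroxypropyl, so within this pair the methyl of compound 2 gives the tighter binding, a comparison that compounds 1 and 2 could not offer with their several differences. Nothing in the data given here accounts for the size or the direction of this step.

The compounds shown leave open whether the step follows the longer chain or its terminal hydroxyl, and a plain propyl group in the same place would separate the two. As far as these compounds go, it also remains open whether an amine, a methyl ether or a carboxylic acid at the end of the chain would give a number closer to that of compound 2.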